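The source may report more compounds than this note shows. Statements on the series, on what has been measured and on what is new or still open speak of the compounds shown alone.

Measured compounds:
- compound 1 `CC(C)(N)C(=O)N[C@H](COCc1ccccc1)c1nnnn1CCOC(=O)NCCO`: 3 nM
- compound 2 `CC(C)(N)C(=O)N[C@H](COCc1ccccc1)c1nnnn1CCOC(=O)NCCCCCO`: 14.6 nM
- compound 3 `CC(C)(N)C(=O)N[C@H](COCc1ccccc1)c1nnnn1CCOC(=O)N1CC[C@@H](O)C1`: 1 nM

These three compounds share one core and differ only in the group attached to the carbonyl carbon at the end of the chain. In a functional assay on H4 cells with growth hormone secretagogue receptor type 1 (Homo sapiens) as the target, read by FLIPR (on this read-out higher numbers stand for an effect only at larger amounts of compound and lower numbers for an effect already at smaller amounts), compound 3 gives 1 nM and thus stands lowest of the three numbers; its steps to the other two, a 3.0-fold lower number from compound 1 to compound 3 (0.48 log units; beyond the scatter) and a 15-fold lower number from compound 2 to compound 3 (1.16 log units; beyond the scatter), both lie beyond the scatter, so compound 3 is the most potent of the measured set.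

Compound 4 `CC1(O)CCN(C(=O)OCCn2nnnc2[C@@H](COCc2ccccc2)NC(=O)C(C)(C)N)C1` is not yet measured. It differs from compound 3 in one place: 3-hydroxy-3-methylpyrrolidin-1-yl in place of 3-hydroxypyrrolidin-1-yl on a carbonyl carbon. Within the data shown here, none of the measured steps changes this ring itself; the steps from compound 1 and compound 2 to compound 3 concern the replacement of an open-chain amine by the ring, not a substituent on the ring. A single added methyl group on an already favourable ring gives no basis to expect a large shift either way, so the expectation for compound 4 in this assay is a step of about a 1.5-fold higher number from compound 3 to compound 4 (0.18 log units; within the scatter), within the scatter. Compound 4 is therefore estimated at 1.5 nM, in the range 0.5 nM to 5 nM.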

Compound 4, half-maximal effective concentration: 10.1 nM
For compound 4 the middle estimate is 6.7-fold (0.83 log units) below the measured one, and the stated range ends below it.
By their numbers in this assay, from the lowest: compound 3; then compound 1; then compounds 4 and 2 (each within the scatter of the next).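

The earlier compounds shown here only compared open-chain amines with the ring, whereas this result shows that a change on the ring itself also matters: 3-hydroxy-3-methylpyrrolidin-1-yl in place of 3-hydroxypyrrolidin-1-yl gives a 10-fold higher number from compound 3 to compound 4 (1.00 log units; beyond the scatter) in this assay. Having a ring at this carbonyl carbon is therefore not enough for a low number: the step is a 3.4-fold higher number from compound 1 to compound 4 (0.53 log units; beyond the scatter), so the open-chain (2-hydroxyethyl)amino group does better here, while a 1.4-fold lower number from compound 2 to compound 4 (0.16 log units; within the scatter) leaves the methylated ring and the (5-hydroxypentyl)amino group level. Nothing measured here explains the size of the step on the ring.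

The compounds shown leave open whether an ethyl group in place of the methyl would read the same way. As far as these compounds go, how the ring would read with a methoxy group in place of the hydroxy, or with no hydroxy at all, as plain pyrrolidin-1-yl, also remains open.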